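Bromo for Acetyl on the Biaryl Acid: Cytotoxicity Outlook

The source may report more compounds than this note shows. Statements on the series, on what has been measured and on what is new or still open speak of the compounds shown alone.

In an ADME assay on HepG2 cells (Homo sapiens) for cytotoxicity, read by CellTiter-Glo and resazurin assay, with a stated time of 72 h (on this read-out lower numbers stand for an effect already at smaller amounts and higher numbers for an effect only at larger amounts of compound), compound 1 `CC(C)N(Cc1cccc(OCCCCCC(=O)O)c1)C(=O)c1ccccc1` gives only a limit, > 26000 nM.
In this assay compound 2 `CC(=O)c1cccc(-c2ccc(C(=O)N(Cc3cccc(OCCCCCC(=O)O)c3)C(C)C)cc2)c1` gives only a limit, > 26000 nM.
In this assay compound 3 `COc1cc(F)cc(-c2ccc(C(=O)N(Cc3cccc(OCCCCCC(=O)O)c3)C(C)C)cc2)c1` gives only a limit, > 26000 nM.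

Compound 2 thus stands at the limit of this assay, together with the two other values; all three share (the limit of > 26000 nM in this assay, at which 3 of the 3 values shown sit). Compound 4 `CC(C)N(Cc1cccc(OCCCCCC(=O)O)c1)C(=O)c1ccc(-c2cccc(Br)c2)cc1` differs from compound 2 by bromo in place of acetyl on an aromatic carbon. The measured steps that touch this part of the shared core are a step that the two limits leave unreadable from compound 1 to compound 2, a step that the two limits leave unreadable from compound 2 to compound 3 and a step that the two limits leave unreadable from compound 1 to compound 3; none of them can be read in size. With no readable step to build on, compound 4 is expected to show no change beyond the scatter, a step that the limit leaves unreadable from compound 2 to compound 4. Compound 4 is therefore estimated at 40000 nM, within 20000 nM to 100000 nM, most likely reported again only as a limit.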

Compound 4, half-maximal effective concentration: > 26000 nM
Compound 4: no number, only a limit; the forecaster's own chance of this, stated with the estimate: 90%; the middle value does not contradict the limit.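

In this assay compound 4 gives only a limit, so no step among compound 1, compound 2, compound 3 and compound 4 can be read in size: the limit of > 26000 nM in this assay, at which 4 of the 4 values shown sit.

The compounds shown leave open whether these four differ at all in this read-out, and at what concentration any of them would show an effect.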